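Swapping a difluorophenyl for a methoxyphenyl on a piperidine

The compounds below may be only part of what the source reports. "The series", "measured", "known", "first", "only" and "open" are said of these compounds alone.

Measured so far:
compound 1, `Fc1ccc(C2CCN(c3ccn4c(CC5CC5)nnc4c3Cl)CC2)c(F)c1`, 61.7 nM;
compound 2, `COc1c(F)cccc1C1CCN(c2ccn3c(CC(F)(F)F)nnc3c2C#N)CC1`, 31 nM;
compound 3, `COc1ccc(F)cc1C1CCN(c2ccn3c(CC(F)(F)F)nnc3c2Cl)CC1`, 10.5 nM.

All three were tested in a functional assay on CHO cells for agonist activity at metabotropic glutamate receptor 2 (Homo sapiens), read by scintillation counting and GTPgammaS binding, with a stated time of 30 min; on this read-out lower numbers stand for an effect already at smaller amounts and higher numbers for an effect only at larger amounts of compound. Compound 1 has the highest number of the three. Its nearest neighbour is compound 2, whose value lies within the usual scatter of compound 1, so the two cannot be told apart on this evidence. Compound 3, on the other hand, gives a clearly lower number than compound 1, a gap that goes beyond the scatter.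

The step to the unmeasured compound 4, `COc1ccccc1C1CCN(c2ccn3c(CC4CC4)nnc3c2Cl)CC1`, touches only the aryl group on the piperidine: 2-methoxyphenyl in place of 2,4-difluorophenyl on a saturated ring carbon. Compound 4 is not a single-change neighbour of compound 2 or compound 3, but both of those carry a methoxy-bearing aryl ring and both give lower numbers than compound 1, which carries the difluorophenyl. On that basis a moderate move toward a lower number is expected for compound 4, rather than no change, though its other substituents differ from those of compounds 2 and 3.

The expected step of a 2.5-fold lower number from compound 1 to compound 4 (0.39 log units; beyond the scatter) is therefore a modest decrease. For compound 4 the estimated value is 25 nM, with a range from 8 nM to 80 nM.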

Compound 4, half-maximal effective concentration: 20 nM
The estimate for compound 4 lay 1.3-fold (0.10 log units) above the measured number; low and high end bracket the measured number.
By their numbers in this assay, from the lowest: compounds 3, 4, 2 and 1 (each within the scatter of the next, the first and the last beyond it).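

Within the data shown here, compound 1 and compound 4 differ only in the aryl group, so this pair gives the first clean reading of this position: 2-methoxyphenyl in place of 2,4-difluorophenyl on a saturated ring carbon gives a 3.1-fold lower number from compound 1 to compound 4 (0.49 log units; beyond the scatter) in this assay. Compounds 2 and 3 also carry a methoxy-bearing aryl ring, but they differ from compound 1 in more than one place, so they could not show that the aryl group alone is enough to shift the number beyond the scatter. The swap exchanges two fluorine atoms for a methoxy group and adds a hydrogen-bond acceptor, but nothing available here links either feature to the shift.

The step cannot yet be divided between losing the fluorines and gaining the methoxy group; a plain phenyl group would help to separate the two, and a 2-ethoxyphenyl group would show whether a longer chain on the oxygen is tolerated. As far as these compounds go, it also remains open whether the same swap would give a similar step on a compound that differs from compound 4 elsewhere, such as one built like compound 3.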